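The source may hold more compounds than are shown below. What is called first, only, known or untested is meant among the compounds shown, and "the series" means these compounds.

Measured in a functional assay for inhibition, with Homo sapiens as the target; on this read-out lower numbers stand for stronger inhibition and higher numbers for weaker inhibition:
- Compound 1 `COc1cc(OC)c(C(=O)/C=C/c2c(Cl)cccc2Cl)c(OC)c1`: 1090 nM
- Compound 2 `COc1cccc(C(=O)/C=C/c2ccccc2)c1OC`: 1670 nM
- Compound 3 `COc1ccccc1C(=O)/C=C/c1ccccc1`: 2230 nM

Compound 3 sits at the top end of these numbers, with 2230 nM. Its nearest neighbour, compound 2, gives 1670 nM, which lies within the scatter of it. Compound 1 gives a lower number, 1090 nM, and that gap lies beyond the scatter.

The next compound to be tested is compound 4 `O=C(/C=C/c1ccccc1)c1ccccc1[N+](=O)[O-]`. It has nitro in place of methoxy on an aromatic carbon, ortho to a large group (nitro in place of methoxy on an aromatic carbon).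

Within the data shown here, only one measured step bears on this change: a 1.3-fold higher number from compound 2 to compound 3 (0.13 log units; within the scatter). There, hydrogen takes the place of methoxy on an aromatic carbon, and the number stays within the scatter. Among the measured compounds shown here, that step offers only limited guidance, since it involves a different replacement and no nitro compound has been measured yet. It does show that losing a methoxy need not move the number much, so no step beyond the scatter is expected in this assay.

The estimated step is a 1.1-fold higher number from compound 3 to compound 4 (0.05 log units; within the scatter). For compound 4 the expected value is 2500 nM, with an estimated range from 900 nM to 7000 nM.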

Compound 4, half-maximal inhibitory concentration: 1520 nM
Estimate against measurement, compound 4: 1.6-fold (0.22 log units) above; low and high end bracket the measured number.
By their numbers in this assay, from the lowest: compounds 1, 4, 2 and 3 (each within the scatter of the next, the first and the last beyond it).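

In this assay, replacing methoxy with nitro on an aromatic carbon, ortho to a large group, gives a 1.5-fold lower number from compound 3 to compound 4 (0.17 log units; within the scatter) and so leaves the read-out within the usual scatter of repeated measurements. Among these compounds, the only earlier step involving a methoxy group simply took it away, giving a 1.3-fold higher number from compound 2 to compound 3 (0.13 log units; within the scatter), whereas this change puts a different group in its stead, with 3 heavy atoms in place of 2 and 2 hydrogen-bond acceptors in place of 1. This place on the ring therefore accepts a real swap of groups, not just a loss, without a step beyond the scatter, though nothing available speaks to the reason for this outcome.

The compounds shown leave open whether an amine or a carboxylic acid at this same place would also stay within the scatter of compound 3 or would produce a clear step. They also leave open whether nitro would behave the same way on the core of compound 1, which differs from compound 3 in more than one place and so cannot be compared with it directly.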